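The source may report more compounds than this note shows. Statements on the series, on what has been measured and on what is new or still open speak of the compounds shown alone.

Working notes on the series. Within the data shown here, compound 1 `O=C(O)CCc1ccc(NCc2ccc(-c3ccccc3)cc2)cc1` is the parent; in a functional assay for agonist activity at Free fatty acid receptor 1 (Homo sapiens) (on this read-out higher numbers stand for an effect only at larger amounts of compound and lower numbers for an effect already at smaller amounts), compound 1 gives 251 nM, the highest of the two numbers measured so far. Among the measured compounds shown here, compound 2 `O=C(O)C1CC1c1ccc(NCc2ccc(-c3ccccc3)cc2)cc1` gives 39.8 nM; the single measured step, a 6.3-fold lower number from compound 1 to compound 2 (0.80 log units; beyond the scatter), concerns the acid-bearing chain and leaves the tail untouched. Compound 3 `O=C(O)CCc1ccc(NCc2cccnc2)cc1` gives a limit only, < 31700 nM. Compound 4 `COc1ccc(CNc2ccc(CCC(=O)O)cc2)cc1` carries methoxy in place of phenyl on an aromatic carbon. For the measured compounds named here, no measured step bears directly on this position: the step from compound 1 to compound 2 alters another part of the core, and compound 3, whose tail also lacks the outer phenyl, shows a limit rather than a number. A weaker effect is therefore expected for compound 4, an estimated step of a 10-fold higher number from compound 1 to compound 4 (1.00 log units; beyond the scatter). Compound 4 is estimated at 2500 nM, within 500 nM to 15000 nM.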

Compound 4, half-maximal effective concentration: 1260 nM
For compound 4 the middle estimate is 2.0-fold (0.30 log units) above the measured one; the measured number falls inside the stated range.
By their numbers in this assay, from the lowest: compound 2; then compound 1; then compound 4.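

In this assay, among these compounds, methoxy in place of phenyl on this aromatic carbon gives a 5.0-fold higher number from compound 1 to compound 4 (0.70 log units; beyond the scatter), the first measured step at this position. Compound 4 still gives a number without the outer ring, so a group of 2 heavy atoms can stand here, at a cost. Compound 3 gives only a limit and not a number, so it provides no second step for the tail: the limit of < 31700 nM in this assay, at which 1 of the 4 values shown sits.

As far as these compounds go, it remains open whether a chlorine or a benzyloxy group here would bring the number closer to that of compound 1. Also open, from the compounds shown here alone, is whether methoxy would cost the same on the 2-carboxycyclopropyl chain of compound 2.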